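The compounds below may be only part of what the source reports. "The series", "measured", "known", "first", "only" and "open" are said of these compounds alone.

Measured so far in a functional assay on NCI-H322M cells (Homo sapiens) for cytotoxicity, read by sulforhodamine B assay, with a stated time of 48 h, tested at 10 uM; on this read-out lower numbers stand for a stronger effect and higher numbers for a weaker effect at the one concentration tested:
- compound 1 `COc1cc(-c2cc(/C=C/C(=O)c3ccc(N)cc3)[nH]n2)cc(OC)c1OC`: -32%
- compound 2 `COc1ccc(-c2cc(/C=C/C(=O)c3ccc(OC)c(OC)c3)[nH]n2)cc1`: -32%
- compound 3 `COc1ccc(-c2cc(/C=C/C(=O)c3ccc(N)cc3)[nH]n2)cc1`: -2%

Compound 1 stands level with compound 2 at the digits shown, and the two together are the lowest of the three numbers; compound 3 lies a fair way higher, a gap that is beyond the usual scatter. Among the measured compounds shown here, no pair among the three differs in only one place, so no single step is available for comparison.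

Compound 4 `COc1ccc(C(=O)/C=C/c2cc(-c3cc(OC)c(OC)c(OC)c3)n[nH]2)cc1OC` is not yet measured. Against compound 1 the change is 3,4-dimethoxyphenyl in place of 4-aminophenyl on a carbonyl carbon. Compounds 2 and 3 share their group on the core and differ in the group on the carbonyl carbon, 4-aminophenyl in compound 3 against 3,4-dimethoxyphenyl in compound 2, and their values fall on opposite sides of the scatter. On that showing a step in this assay from compound 1 to compound 4 is expected to run downward by a size beyond the scatter, a number 18 percentage points lower from compound 1 to compound 4 (beyond the scatter). For compound 4 the value expected in this assay is -50%, between -75% and -20%.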

Compound 4, a percentage reported as activity, at one concentration (the size of the read-out at that concentration, not a potency): -96%
The estimate for compound 4 lay 46 percentage points above the measured number; measured number outside the range, below it.
By their numbers in this assay, from the lowest: compound 4; then compounds 1 and 2 (each within the scatter of the next); then compound 3.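

In this assay, putting 3,4-dimethoxyphenyl in place of 4-aminophenyl on a carbonyl carbon gives a number 64 percentage points lower from compound 1 to compound 4 (beyond the scatter). Among the compounds shown here, this is the first direct reading of this position, since no earlier pair differed in one place only, and it shows that this change alone, with the rest of compound 1 kept, moves the read-out by a large step. The data at hand offer nothing that bears on the reason for the step.

Open, as far as these compounds go, is which part of the entering group carries the step: a 4-methoxyphenyl, a 3-methoxyphenyl or an unsubstituted phenyl on the carbonyl carbon would divide it. Also open, from the compounds shown here alone, is whether the same change gives a step of similar size with another group on the core, such as a 4-methoxyphenyl in place of the trimethoxyphenyl of compound 1.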